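Methylsulfanyl in Place of Dimethylamino on the Shared Core

The source may hold more compounds than are shown below. What is called first, only, known or untested is meant among the compounds shown, and "the series" means these compounds.

Measured compounds:
compound 1, `Nc1nccc2c1ncn2[C@H]1C[C@H](O)[C@@H](CO)O1`: 10 mg/kg
compound 2, `CN(C)c1nccc2c1ncn2[C@H]1C[C@H](O)[C@@H](CO)O1`: > 9 mg/kg

In a functional assay on the whole organism (Pleural cavity) with Rattus norvegicus as the target (on this read-out lower numbers stand for an effect already at smaller amounts and higher numbers for an effect only at larger amounts of compound), compound 1 gives 10 mg/kg. For compound 2 the reading of > 9 mg/kg in this assay is a limit of the assay and not a number. The step that the limit leaves unreadable from compound 1 to compound 2 therefore cannot be read, as the limit of > 9 mg/kg in this assay, at which 1 of the 2 values shown sits, shows, and compound 2 stands only at that limit.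

Compound 3, `CSc1nccc2c1ncn2[C@H]1C[C@H](O)[C@@H](CO)O1`, differs from compound 2 by methylsulfanyl in place of dimethylamino on an aromatic carbon. Among the measured compounds shown here, the single measured step, the one from compound 1 to compound 2, is unreadable and concerns a different change, so the data give no readable precedent for this replacement. In this assay no step beyond the usual scatter is expected in either direction; the expected step is a step that the limit leaves unreadable from compound 2 to compound 3. Compound 3 is therefore estimated at 10 mg/kg, with a range from 3 mg/kg to 30 mg/kg.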

Compound 3, dose for half-maximal effect: > 9 mg/kg
Compound 3 ended at the assay's limit (the forecaster's own chance of this, stated with the estimate: 50%); the middle value lies beyond the limit too.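

No step from compound 1 or compound 2 to compound 3 can be read in this assay, because these comparisons stop at a limit of the assay: the limit of > 9 mg/kg in this assay, at which 2 of the 3 values shown sit.

The compounds shown leave open whether methylsulfanyl, dimethylamino and amino differ at all on this read-out.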